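This account rests on a few compounds, and the source may have more. Where it says the series, first, only, none or still open, it means among the compounds named here.

Three related compounds have been measured in a functional assay on PC-3 cells (Homo sapiens) for cytotoxicity, read by MTT assay, with a stated time of 72 h (on this read-out lower numbers stand for stronger inhibition and higher numbers for weaker inhibition), and two of them return no number. Compound 1 `CNC(=O)c1cc(Oc2ccc(NC(=O)c3cc(-c4ccc(C(F)(F)F)cc4)ncn3)cc2F)ccn1` stands at a limit of the assay, > 100000 nM, so its true position is not known. Compound 2 `CNC(=O)c1cc(Oc2ccc(NC(=O)c3cc(-c4ccc(Cl)cc4)ncn3)cc2)ccn1` also gives only a limit, > 100000 nM. Compound 3 `CNC(=O)c1cc(Oc2ccc(NC(=O)c3nccc(-c4ccc(OC)cc4)n3)cc2)ccn1` is the only one of the three with a measured number, 14200 nM.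

The next compound to be tested, compound 4 `CNC(=O)c1cc(Oc2ccc(NC(=O)c3cc(-c4ccc(OC)cc4)ncn3)cc2F)ccn1`, keeps the core of compound 1 and changes a single substituent: methoxy in place of trifluoromethyl on an aromatic carbon. In words, methoxy takes the place of trifluoromethyl on an aromatic carbon, turning 4-(trifluoromethyl)phenyl into 4-methoxyphenyl.

For the measured compounds named here, no step between measured compounds is available to size this change directly. The expectation rests on compound 3, which also carries 4-methoxyphenyl and gives 14200 nM. That is a single compound, so the expectation remains loose. In this assay, the expected change is an at least 2.8-fold lower number from compound 1 to compound 4 (0.45 log units; beyond the scatter), in the direction of stronger inhibition, though another limit reading would not be surprising. For compound 4, the estimated half-maximal inhibitory concentration is 35000 nM, with an expected range from 10000 nM to 100000 nM.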

Compound 4, half-maximal inhibitory concentration: 56200 nM
Compound 4: middle estimate off by 1.6-fold (0.21 log units), on the low side; the measured number falls inside the stated range.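

With compound 4, the series gains its first step in this assay between compounds that differ in one place, and methoxy in place of trifluoromethyl gives an at least 1.7-fold lower number from compound 1 to compound 4 (0.25 log units; that floor lies within the scatter). This size is only a floor and not a measured gap, because compound 1 gives no number of its own: the limit of > 100000 nM in this assay, at which 2 of the 4 values shown sit. What the result adds is that a compound on the core of compound 1 returns a number once this position, para to a large group, carries methoxy, although the floor alone does not show a change beyond the usual scatter.

On these data alone, how far compound 1 truly lies from compound 4 remains open, as does the effect of the other differences among the compounds, since compound 2 and compound 3 each differ from compound 4 in more than one place. As far as these compounds go, it also remains open whether a different group at this position, such as an amine, a carboxylic acid or a longer chain like ethoxy, would give a lower number than methoxy or would return to a limit.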